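The source may hold more compounds than are shown below. What is called first, only, known or untested is meant among the compounds shown, and "the series" means these compounds.

Compound 1 `COc1ccc2c(c1)CCC=C2CCCN1CCc2cc(OC)c(OC)cc2C1` and compound 2 `COc1cc2c(cc1OC)CN(CCCC1=CCCc3cc(OC)c(OC)cc31)CC2` share one core and differ by a single change: methoxy in place of hydrogen on an aromatic carbon. In an ADME assay on Caco-2 cells (Homo sapiens) for permeability, in the apical to basolateral direction (a higher number here means that the compound crosses the layer faster, a lower number that the compound crosses the layer more slowly), compound 1 gives 407 nm/s, while compound 2 gives 672 nm/s. The step is a 1.7-fold higher number from compound 1 to compound 2 (0.22 log units; within the scatter). Compound 3 `COc1ccc2c(c1)CCCC2CCCN1CCc2cc(OC)c(OC)cc2C1` is built on a second core; the difference between the two cores is not broken down here. In this assay compound 3 gives 828 nm/s. Compound 4 `COc1cc2c(cc1OC)CN(CCCC1CCCc3cc(OC)c(OC)cc31)CC2` has not yet been measured. It differs from compound 3 by methoxy in place of hydrogen on an aromatic carbon, the same change as that between compound 1 and compound 2, at a place described in the same words. For compound 4 a step of a 1.2-fold higher number from compound 3 to compound 4 (0.08 log units; within the scatter) in this assay is expected, resting on the single earlier pairing, whose step was a 1.7-fold higher number from compound 1 to compound 2 (0.22 log units; within the scatter) and stayed within the scatter. Compound 4 is therefore estimated at 1000 nm/s, with a likely range from 600 nm/s to 1700 nm/s.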

Compound 4, apparent permeability: 868 nm/s
For compound 4 the middle estimate is 1.2-fold (0.06 log units) above the measured one; the range from low to high includes it.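

Methoxy in place of hydrogen on an aromatic carbon gives a 1.0-fold higher number from compound 3 to compound 4 (0.02 log units; within the scatter) in this assay, and this step does not differ from the earlier one: the same change on two cores in this assay, a 1.7-fold higher number (0.22 log units; within the scatter) from compound 1 to compound 2 and a 1.0-fold higher number (0.02 log units; within the scatter) from compound 3 to compound 4, 1.6-fold (0.20 log units) apart, within the scatter of two such steps. Across these two cores the change therefore carries over without a difference that can be told from the scatter. Neither step lies beyond the scatter, so the pairs do not show that the change itself moves the number, and two cores give no rule for any further core in the series.

As far as these compounds go, whether an ethoxy group or a fluorine on this aromatic carbon would behave as methoxy does stays open. So does whether the step would hold on a core with a longer chain.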